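The compounds below may be only part of what the source reports. "The series", "measured", "known", "first", "only" and "open" are said of these compounds alone.

Compound 1 `O=C(Nc1nccs1)c1cccc(Nc2ncc(F)c(Nc3ccc(F)cc3)n2)c1`: > 10000 nM
Compound 2 `O=C(Nc1cccc(Nc2ncc(F)c(Nc3ccc(F)cc3)n2)c1)c1cnccn1`: 23600 nM

Within the data shown here, in a functional assay on KB cells (Homo sapiens) for antiproliferative activity, read by sulforhodamine B assay, with a stated time of 3 days (a lower number here means a stronger inhibitor of growth, a higher number a weaker inhibitor of growth), compound 2 gives 23600 nM, the only actual number so far. Compound 1 gives > 10000 nM, which is a limit of the assay and not a number. Among the measured compounds shown here, the sole evidence on the measured steps is the limit of > 10000 nM in this assay, at which 1 of the 2 values shown sits. As a result, a step that the limit leaves unreadable from compound 1 to compound 2 offers no size to carry forward.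

Compound 3 `O=C(Nc1cccc(Nc2ncc(F)c(Nc3ccc(F)cc3)n2)c1)c1cccc([N+](=O)[O-])c1` keeps the shared core and changes one group, 3-nitrophenyl in place of pyrazin-2-yl on a carbonyl carbon. For the measured compounds named here, no measured step shows what this change does, so the expectation starts from compound 2 at 23600 nM, with no shift beyond the scatter expected in either direction. The expected change is a 1.2-fold lower number from compound 2 to compound 3 (0.07 log units; within the scatter). Compound 3 is estimated at 20000 nM, with an expected range of 7000 nM to 50000 nM.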

Compound 3, concentration for 50% growth inhibition: 15100 nM
Estimate against measurement, compound 3: 1.3-fold (0.12 log units) above; the measured number falls inside the stated range.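

Among these compounds, this is the first step on this carbonyl carbon that can be read: in this assay, 3-nitrophenyl in place of pyrazin-2-yl gives a 1.6-fold lower number from compound 2 to compound 3 (0.19 log units; within the scatter). An aromatic ring of carbon only, bearing a nitro group, can therefore replace the ring with two hetero atoms without a shift beyond the scatter. Compound 1 gives > 10000 nM, which is a limit and not a number, so the step from compound 1 to compound 2 cannot be read: the limit of > 10000 nM in this assay, at which 1 of the 3 values shown sits.

Still open, from the compounds shown here alone, is whether any group on this carbonyl carbon can move the number beyond the scatter, and a 3-aminophenyl or a 3-carboxyphenyl group would test this. Also open, going by these compounds, is whether the nitro group matters apart from its ring, a question that plain phenyl would address.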